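Aryl-amine variation on the shared core: compound 2 to compound 4

The source may report more compounds than this note shows. Statements on the series, on what has been measured and on what is new or still open speak of the compounds shown alone.

The series keeps one core and changes the group on the amine. Compound 1 `FC(F)(F)c1ccc(CSc2nc(N3CCCCC3)c3ccccc3n2)cc1` carries piperidin-1-yl. In a functional assay on HGC-27 cells (Homo sapiens) for cytotoxicity, read by MTT assay, with a stated time of 72 h (on this read-out higher numbers stand for weaker inhibition and lower numbers for stronger inhibition), compound 1 sits at a limit of the assay, > 50000 nM. Compound 2 `FC(F)(F)c1ccc(CSc2nc(Nc3ccccc3Cl)c3ccccc3n2)cc1` carries (2-chlorophenyl)amino. In this assay compound 2 also sits at a limit, > 50000 nM. Going by the values given here, compound 3 `FC(F)(F)c1ccc(CSc2nc(Nc3cccc(C(F)(F)F)c3)c3ccccc3n2)cc1` carries (3-(trifluoromethyl)phenyl)amino, and in this assay compound 3 gives 11700 nM, the only plain number of the three. The step that the two limits leave unreadable from compound 1 to compound 2 cannot be read, while an at least 4.2-fold lower number from compound 1 to compound 3 (0.63 log units; beyond the scatter) and an at least 4.2-fold lower number from compound 2 to compound 3 (0.63 log units; beyond the scatter) both leave the limit behind. Compound 2 thus stands at the limit of > 50000 nM in this assay, at which 2 of the 3 values shown sit, together with compound 1.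

Compound 4 `Fc1ccc(Nc2nc(SCc3ccc(C(F)(F)F)cc3)nc3ccccc23)cc1Cl` is not yet measured. Against compound 2 the change is 3-chloro-4-fluorophenyl in place of 2-chlorophenyl on a nitrogen on an aromatic ring.

Among the compounds with values here, the one measured step from compound 2 is an at least 4.2-fold lower number from compound 2 to compound 3 (0.63 log units; beyond the scatter), where a different substituted phenyl on the same nitrogen moved away from the limit. Compound 4 also replaces the 2-chlorophenyl, so a step in the same direction is expected, though its size is uncertain and a reading at the limit remains possible. For compound 4 a step of an at least 2.5-fold lower number from compound 2 to compound 4 (0.39 log units; beyond the scatter) is expected. Compound 4 is estimated at 20000 nM in this assay, within 6000 nM to 60000 nM.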

Compound 4, half-maximal inhibitory concentration: 14700 nM
For compound 4 the middle estimate is 1.4-fold (0.13 log units) above the measured one; measured number inside the range.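

In this assay there is now an at least 3.4-fold lower number from compound 2 to compound 4 (0.53 log units; beyond the scatter) and an at least 3.4-fold lower number from compound 1 to compound 4 (0.53 log units; beyond the scatter) with a second substituted phenyl on the nitrogen, so the move away from the limit no longer rests on the 3-(trifluoromethyl)phenyl of compound 3 alone. The two aryl groups that give plain numbers do not separate, with a 1.3-fold higher number from compound 3 to compound 4 (0.10 log units; within the scatter) between 3-(trifluoromethyl)phenyl and 3-chloro-4-fluorophenyl, so no order between compound 3 and compound 4 can be drawn in this assay from these data. Any pattern that a substituted phenyl on this nitrogen leaves the limit has compound 2 against it, and the entries for compound 1 and compound 2 are limits and not numbers: the limit of > 50000 nM in this assay, at which 2 of the 4 values shown sit.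

The compounds shown do not tell which feature of the aryl group separates compound 2 from compound 3 and compound 4, and the true size of that gap stays open while compound 2 is only a limit. They also leave open how the read-out would respond to a carboxylic acid or an aminomethyl group on the phenyl in place of the halogens.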